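This account rests on a few compounds, and the source may have more. Where it says the series, first, only, none or still open, it means among the compounds named here.

In an assay on isolated protein for inhibition of DNA topoisomerase 1 (Homo sapiens), with a stated time of 30 min, tested at 100 uM (a lower number here means a weaker effect, a higher number a stronger effect of the compound at the concentration tested), two compounds have been measured. Compound 1 `Oc1ccc(-c2cc(-c3ccncc3)nc(-c3ccccc3Cl)c2)cc1` gives 9.9%, while compound 2 `Oc1ccc(-c2cc(-c3ccc(Cl)cc3)nc(-c3ccsc3)c2)cc1` gives 47.7%. Compound 2 thus stands highest of the two numbers, and its nearest neighbour, compound 1, lies below it by a gap beyond the usual scatter. The two differ from each other in two places, so no single step can be read between them.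

Compound 3 `Oc1ccc(-c2cc(-c3ccsc3)nc(-c3ccccc3Cl)c2)cc1` has not yet been measured in this assay. It differs from compound 2 in one place (2-chlorophenyl in place of 4-chlorophenyl on an aromatic carbon). Compound 3 shares its 2-chlorophenyl group with compound 1, which gives 9.9%, and that is the only hint available. The step from compound 2 to compound 3 is therefore expected to be downward and beyond the scatter, in the order of a number 22.7 percentage points lower from compound 2 to compound 3 (beyond the scatter). Compound 3 is expected to give 25%, with a range from 5% to 50%.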

Compound 3, a percentage reported as inhibition, at one concentration (the size of the read-out at that concentration, not a potency): 4.1%
Compound 3: the middle estimate sits 20.9 percentage points above what was measured; measured number below the stated range.
By their numbers in this assay, from the lowest: compounds 3 and 1 (each within the scatter of the next); then compound 2.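

In this assay, the same atoms joined differently on the aromatic carbon next to the ring nitrogen, with 2-chlorophenyl in place of 4-chlorophenyl, give a number 43.6 percentage points lower from compound 2 to compound 3 (beyond the scatter), so with thiophen-3-yl in the shared core the read-out depends on where the chlorine sits on this phenyl group. With 2-chlorophenyl held fixed, thiophen-3-yl in place of pyridin-4-yl gives a number 5.8 percentage points lower from compound 1 to compound 3 (within the scatter), and in this pair those two groups cannot be told apart, both compounds lying low in the read-out. Nothing available explains the effect of moving the chlorine.

Going by these compounds, it remains open whether 4-chlorophenyl would keep its higher read-out with pyridin-4-yl in place of thiophen-3-yl. Also open, on these data alone, is what a 3-chlorophenyl, an unsubstituted phenyl or a 4-methoxyphenyl group would give on this carbon.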